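The compounds below may be only part of what the source reports. "The series", "measured", "known", "first", "only" and "open" are said of these compounds alone.

Measured compounds: compound 1 `Cc1cccc(-c2cnc(N)nc2-c2ccccc2)c1`, compound 2 `Cc1ccc(-c2cnc(N)nc2-c2ccccc2)cc1`, compound 3 `COc1ccccc1-c1cnc(N)nc1-c1ccccc1`.

Three compounds sharing one core were tested in an assay on CHO cells for displacement of a labelled ligand from adenosine receptor A1 (Homo sapiens), read by scintillation counting, with a stated time of 1 h, tested at 1 uM; on this read-out lower numbers stand for less inhibition and higher numbers for more inhibition at the one concentration tested (going by the name of the read-out). For compound 1 the read-out is a limit of this assay, > 80%, and not a number; the limit of > 80% in this assay, at which 1 of the 3 values shown sits, concerns compound 1 alone. Among the two proper numbers, compound 2 gives 51%, the highest of them, while compound 3 gives 20%, a gap that lies beyond the usual scatter of repeated measurements. For the measured compounds named here, no pair of measured compounds differs in a single place, so compound 2 and compound 3 show only their two values side by side.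

The next compound, compound 4 `COc1ccc(-c2cnc(N)nc2-c2ccccc2)cc1`, differs from compound 2 by one change:

methoxy in place of methyl on an aromatic carbon

Methoxy appears among the measured compounds only in compound 3, and no measured step from compound 2 or compound 3 to compound 4 exists, so the expectation rests on the change itself. In this assay a modest downward step is expected from compound 2 to compound 4, of a size that may not clearly exceed the scatter. Compound 4 is expected to give 40%, within a range from 15% to 65%. The step from compound 2 to compound 4 that this estimate means is a number 11 percentage points lower from compound 2 to compound 4 (beyond the scatter), an expectation rather than a measurement.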

Compound 4, a percentage reported as inhibition, at one concentration (the size of the read-out at that concentration, not a potency): 56%
For compound 4 the middle estimate is 16 percentage points below the measured one; the measured number falls inside the stated range.
By their numbers in this assay, from the lowest: compound 3; then compounds 2 and 4 (each within the scatter of the next). At a limit, above all of these: compound 1.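

In this assay the exchange of methyl for methoxy gives a number 5 percentage points higher from compound 2 to compound 4 (within the scatter) and is the only single-place comparison among the compounds shown. On an aromatic carbon para to a large group, this assay therefore does not separate the two groups, although methoxy brings an oxygen, counted as a hydrogen-bond acceptor, where methyl has none. Methoxy also does not by itself go with the low number of compound 3 (20%), since compound 4 carries it too and gives 56% in the same assay.

Compound 1 stands apart as a limit of this assay and not a number, so its place relative to the others cannot be sized: the limit of > 80% in this assay, at which 1 of the 4 values shown sits. As far as these compounds go, whether an amine, a carboxylic acid or a longer chain at this position would keep the reading shared by compound 2 and compound 4 stays open, as does whether that reading would hold on any other receptor.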